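From Trifluoromethyl to Methyl on a Shared Core

This account rests on a few compounds, and the source may have more. Where it says the series, first, only, none or still open, it means among the compounds named here.

Of the compounds shown here, two sharing one core have been measured so far. In a functional assay on K562/A02 cells (Homo sapiens) for antiproliferative activity, read by MTT assay (on this read-out lower numbers stand for stronger inhibition and higher numbers for weaker inhibition), compound 1 `C/C(=N\NC(=S)NCCCCCC(=O)NO)c1cccc(Br)c1` gives 520 nM, and compound 2 `C/C(=N\NC(=S)NCCCCCC(=O)NO)c1cccc(C(F)(F)F)c1` gives 890 nM. Within the data shown here, the only measured step is a 1.7-fold higher number from compound 1 to compound 2 (0.23 log units; within the scatter), so compound 2 cannot be told apart from the one neighbour it has on these numbers. That step exchanges bromo for trifluoromethyl on an aromatic carbon.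

The next structure, compound 3 `C/C(=N\NC(=S)NCCCCCC(=O)NO)c1cccc(C)c1`, has not yet been measured. It carries methyl in place of trifluoromethyl on an aromatic carbon. The core stays untouched, and the change is again a swap of one small group on the aromatic carbon. Among the measured compounds shown here, no measured pair shows this exact exchange, so the evidence is thin and sets no firm direction. For the measured compounds named here, the one related exchange, a 1.7-fold higher number from compound 1 to compound 2 (0.23 log units; within the scatter), stayed within the scatter, so a similarly modest result is expected in this assay. The expected step is a 1.4-fold lower number from compound 2 to compound 3 (0.14 log units; within the scatter), which would be no real change. For compound 3 the estimated value is 650 nM, with an expected range from 280 nM to 1500 nM.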

Compound 3, half-maximal inhibitory concentration: 3570 nM
For compound 3 the middle estimate is 5.5-fold (0.74 log units) below the measured one; measured number outside the range, above it.
By their numbers in this assay, from the lowest: compounds 1 and 2 (each within the scatter of the next); then compound 3.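

At this place on the aromatic ring, the choice of group now makes a visible difference in this assay: methyl in place of trifluoromethyl gives a 4.0-fold higher number from compound 2 to compound 3 (0.60 log units; beyond the scatter), and methyl in place of bromo gives a 6.9-fold higher number from compound 1 to compound 3 (0.84 log units; beyond the scatter). Both steps lie beyond the usual scatter, whereas the earlier exchange between bromo and trifluoromethyl stayed within it, so the position is not indifferent to what sits on it. Bromo and trifluoromethyl cannot be told apart on these numbers, while methyl stands apart as the weakest of the three, and nothing shown here explains why.

Three groups at one place are too few to show whether the weaker result belongs to methyl alone or would also appear with groups such as chloro, methoxy or an amine. Going by these compounds, it also remains open whether the same order would hold with these groups elsewhere on the ring, or with a longer chain on the shared core.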